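The compounds below may be only part of what the source reports. "The series", "measured", "known", "first", "only" and "open" are said of these compounds alone.

Measured compounds:
Compound 1 `CCC(C)COC(=O)Nc1nc(=O)n([C@@H]2O[C@H](C)[C@H]3OC(=O)O[C@H]32)cc1F` gives 70 ug/mL in a functional assay on MCF7 cells (Homo sapiens) for cytotoxicity, read by MTT assay, with a stated time of 3 days; on this read-out higher numbers stand for weaker inhibition and lower numbers for stronger inhibition
Compound 2 `CCC(C)COC(=O)Nc1nc(=O)n([C@@H]2O[C@H](C)[C@@H](O)[C@H]2O)cc1F` gives 120 ug/mL in this assay
Compound 3 `CC(C)CCOC(=O)Nc1nc(=O)n([C@@H]2O[C@H](C)[C@H]3OC(=O)O[C@H]32)cc1F` gives 100 ug/mL in this assay

Compound 1 and compound 3 share a core and differ by isobutyl in place of sec-butyl on a saturated chain carbon bound to an oxygen next to a carbonyl group; the step of a 1.4-fold higher number from compound 1 to compound 3 (0.15 log units; within the scatter) is within the scatter, so these two numbers cannot be told apart. Compound 2 carries a different core; the difference between the two cores is not broken down here. All three numbers sit within the scatter of one another.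

Compound 4 `CC(C)CCOC(=O)Nc1nc(=O)n([C@@H]2O[C@H](C)[C@@H](O)[C@H]2O)cc1F` has not been measured. It stands to compound 2 as compound 3 stands to compound 1, by isobutyl in place of sec-butyl on a saturated chain carbon bound to an oxygen next to a carbonyl group, made at the same place. The step expected from compound 2 to compound 4 is a 1.3-fold higher number from compound 2 to compound 4 (0.10 log units; within the scatter), resting on the earlier step of a 1.4-fold higher number from compound 1 to compound 3 (0.15 log units; within the scatter). For compound 4 the value expected in this assay is 150 ug/mL, ranging from 70 ug/mL to 320 ug/mL.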

Compound 4, half-maximal inhibitory concentration: 120 ug/mL
For compound 4 the middle estimate is 1.3-fold (0.10 log units) above the measured one; the measured number falls inside the stated range.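

In this assay, isobutyl in place of sec-butyl on the second core gives no change at the digits printed from compound 2 to compound 4 (within the scatter), and the two steps can be set side by side: the same change on two cores in this assay, a 1.4-fold higher number (0.15 log units; within the scatter) from compound 1 to compound 3 and no change at the digits printed (within the scatter) from compound 2 to compound 4, 1.4-fold (0.15 log units) apart, within the scatter of two such steps The change therefore carries from one core to the other with no difference that can be told apart, and the chain swap moves the number beyond the scatter on neither core. This is agreement between two steps too small to read, so it shows no transferable gain or loss and favours neither chain.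

On these data alone, whether a longer chain or a chain ending in an amine at the same place would give a step beyond the scatter stays open. As far as these compounds go, whether the two cores would still behave alike with such a larger step also stays open.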